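Bromo in Place of Cyclohexyl on the Shared Core

The compounds below may be only part of what the source reports. "The series", "measured", "known", "first", "only" and "open" are said of these compounds alone.

Measured compounds:
compound 1 `CC1(C)N=C(N)N=C(N)N1c1cccc(F)c1` gives 7.94
compound 2 `CC1(C)N=C(N)N=C(N)N1c1cccc(C2CCCCC2)c1` gives 7.97
compound 3 `CCCCCCCCCCCCOc1cccc(N2C(N)=NC(N)=NC2(C)C)c1` gives 6.41

In a functional assay on L5178Y cells (Mus musculus) for inhibition (on this read-out higher numbers stand for higher potency (the scale is a negative logarithm) and lower numbers for lower potency), compound 2 stands highest of the three, though compound 1 sits beside it within the scatter, while compound 3 lies far lower. Compound 4 `CC1(C)N=C(N)N=C(N)N1c1cccc(Br)c1` is the unmeasured partner of compound 2; the change is bromo in place of cyclohexyl on an aromatic carbon. Within the data shown here, the one step that bears on it is a number 0.03 log units higher from compound 1 to compound 2 (within the scatter), where a small halogen and the cyclohexyl gave the same result. A bromo group on the same aromatic carbon is therefore expected to leave the number about where compound 2 stands, so the step of a number 0.03 log units higher from compound 2 to compound 4 (within the scatter) is estimated to fall within the scatter. Compound 4 is estimated at 8, with a range from 7.5 to 8.5.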

Compound 4, logarithm of the reciprocal of the active concentration, log(1/C): 8.42
Compound 4: middle estimate off by 0.42 log units, on the low side; low and high end bracket the measured number.
By their numbers in this assay, from the lowest: compound 3; then compounds 1 and 2 (each within the scatter of the next); then compound 4.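

In this assay, the group on this aromatic carbon turns out to matter: bromo in place of cyclohexyl gives a number 0.45 log units higher from compound 2 to compound 4 (beyond the scatter), and bromo in place of fluoro gives a number 0.48 log units higher from compound 1 to compound 4 (beyond the scatter), whereas the earlier step between fluoro and cyclohexyl stayed within the scatter. Fluoro and bromo are each a single atom, yet only bromo separates from the others, so the number of atoms in the group does not by itself order these compounds. Nothing shown here accounts for the rise with bromo.
From the compounds shown here alone, whether chloro or iodo on the same carbon would match bromo remains open, as does the outcome with an amine or a carboxylic acid there.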